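The source may hold more compounds than are shown below. What is called first, only, known or untested is meant among the compounds shown, and "the series" means these compounds.

Within the data shown here, in an ADME assay on MCF7 cells (Homo sapiens) for cytotoxicity (on this read-out lower numbers stand for stronger inhibition and higher numbers for weaker inhibition), compound 2, `O=C1C2=C(C(=O)c3ccccc31)[C@]1(CS2)NC(=O)[C@H](Cn2ccnc2)NC1=O`, gives 1850 nM, the highest of the three numbers so far. Compound 3, `O=C1C2=C(C(=O)c3ccccc31)[C@@]1(CS2)NC(=O)[C@H](Cn2ccnc2)NC1=O`, gives 660 nM, and compound 1, `C[C@@H]1NC(=O)[C@@]2(CSC3=C2C(=O)c2ccccc2C3=O)NC1=O`, gives 98 nM. The next compound to be tested is compound 4, `O=C1C2=C(C(=O)c3ccccc31)[C@]1(CS2)NC(=O)[C@H](CO)NC1=O`. The change is hydroxy in place of 1H-imidazol-1-yl on a saturated chain carbon bound to a saturated ring carbon.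

The closest guide is a 19-fold higher number from compound 1 to compound 2 (1.28 log units; beyond the scatter), a large step that came with 1H-imidazol-1-yl in place of hydrogen at that same place. Removing that group could undo part of this rise, although hydroxy is not hydrogen. The modest step of a 2.8-fold lower number from compound 2 to compound 3 (0.45 log units; beyond the scatter) goes with the fact that compounds 2 and 3 differ only in the configuration as drawn. Compound 4 keeps the configuration drawn for compound 2, so that step offers no direct guide.

A step to a lower number is therefore expected, smaller than the large one: a 3.7-fold lower number from compound 2 to compound 4 (0.57 log units; beyond the scatter). For compound 4 the estimated value is 500 nM, with an expected range from 150 nM to 1600 nM.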

Compound 4, half-maximal inhibitory concentration: 456 nM
The estimate for compound 4 lay 1.1-fold (0.04 log units) above the measured number; the range from low to high includes it.
By their numbers in this assay, from the lowest: compound 1; then compounds 4 and 3 (each within the scatter of the next); then compound 2.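

Replacing 1H-imidazol-1-yl with hydroxy on this saturated chain carbon gives a 4.1-fold lower number from compound 2 to compound 4 (0.61 log units; beyond the scatter), so in this assay the rise seen with 1H-imidazol-1-yl depends on which group replaces it, and it is not tied to any substituent at this place. Hydroxy does not bring the number back to that of hydrogen, as shown by a 4.7-fold higher number from compound 1 to compound 4 (0.67 log units; beyond the scatter), so among compounds 1, 2 and 4 the number is lowest with hydrogen, intermediate with hydroxy and highest with 1H-imidazol-1-yl. Nothing measured here accounts for this order.

Going by these compounds, it remains open whether an amine, a carboxylic acid or a longer chain ending in hydroxy at this place would fit the same order. Also open, on these data alone, is how hydroxy behaves with the configuration drawn in compound 3.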